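The compounds below may be only part of what the source reports. "The series", "measured", "known", "first", "only" and "open" are said of these compounds alone.

Measured so far:
- compound 1, `CCC(C(=O)N1CCN(c2cccc(C(F)(F)F)c2)CC1)N1C(=O)CC(C)C1=O`: in a functional assay on the whole organism (strain Swiss) with Mus musculus as the target, with a stated time of 0.25 h (on this read-out higher numbers stand for an effect only at larger amounts of compound and lower numbers for an effect already at smaller amounts), compound 1 gives 30.3 mg/kg
- compound 2, `Cc1cccc(N2CCN(C(=O)C(C)N3C(=O)CC(C)C3=O)CC2)c1`: in this assay compound 2 gives "not determined" (no result reported), that is, no result reported
- compound 3, `CC(C(=O)N1CCN(c2ccccc2C(F)(F)F)CC1)N1C(=O)CC(C)(C)C1=O`: in this assay compound 3 gives "not determined" (no result reported), that is, no result reported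

Where compound 2 stands: it has no number at all in this assay, and the same holds for compound 3, so only compound 1 carries a value in the series. Among the measured compounds shown here, no single step between measured compounds exists in this assay, and nothing can be said about how compound 2 compares with any other member.

Compound 4, `CC1CC(=O)N(C(C)C(=O)N2CCN(c3cccc(C(F)(F)F)c3)CC2)C1=O`, is the next candidate for this assay. It differs from compound 2 by trifluoromethyl in place of methyl on an aromatic carbon. For the measured compounds named here, because compound 2 has no value, no direction or size can be read off for this change from the data; the only anchor is compound 1, which shares the trifluoromethyl-bearing arrangement with compound 4. In this assay compound 1 gives 30.3 mg/kg. Compound 4 is expected to land close to that, estimated at 30 mg/kg with a range from 10 mg/kg to 90 mg/kg.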

Compound 4, dose for half-maximal effect: 24.6 mg/kg
The estimate for compound 4 lay 1.2-fold (0.09 log units) above the measured number; low and high end bracket the measured number.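

In this assay the series gains its first readable step: hydrogen in place of methyl on the saturated chain carbon gives a 1.2-fold lower number from compound 1 to compound 4 (0.09 log units; within the scatter) and so leaves the read-out unchanged within the scatter. With trifluoromethyl held on the aromatic ring, the side chain of compound 1 and the side chain of compound 4 cannot be told apart on this read-out, so this place tolerates the change in this one pair. The step from methyl to trifluoromethyl on the aromatic carbon cannot be read, as compound 2 has no number.

The compounds shown leave open how a longer chain, a hydroxyl group or an amine would read in that chain position. They also leave open whether the same tolerance holds with a chlorine atom in place of trifluoromethyl on the aromatic ring.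

No supporting data bear on this result.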